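Phenoxy in Place of Phenethyl: An Expected Step

A few compounds are considered here, and "the series" means these few. Any claim that something is new, unique, unknown or untested is made for them only; others in the source may bear on it.

Of the compounds shown here, three on a shared core have been measured in a functional assay on HEK293 cells for antagonist activity at proteinase-activated receptor 4 (Homo sapiens), read by FLIPR and calcium flux, with a stated time of 30 min; a higher number here means a weaker inhibitor, a lower number a stronger inhibitor. Compound 3 `COc1cc(OCc2cccc(CCc3ccccc3)c2)c2cc(-c3cn4nc(OC)sc4n3)oc2c1` gives 2.4 nM, the lowest number of the three, and since both of its steps to the other two lie beyond the usual scatter, it is the strongest inhibitor of the set. Compound 1 `COc1cc(OCc2ccccc2OC)c2cc(-c3cn4nc(OC)sc4n3)oc2c1`, which carries a smaller benzyl ether on the same core, gives 19 nM. Compound 2 `CCSc1nn2cc(-c3cc4ccccc4o3)nc2s1`, which lacks the ether side chain and the ring methoxy groups altogether, gives 2900 nM, far above the other two.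

Compound 4 `COc1cc(OCc2cccc(Oc3ccccc3)c2)c2cc(-c3cn4nc(OC)sc4n3)oc2c1` has not yet been measured. It differs from compound 3 in one place: phenoxy in place of phenethyl on an aromatic carbon. Going by the values given here, no measured pair shows this particular exchange, so its effect cannot be read from the data. Both the group that leaves and the group that enters hold one six-membered aromatic ring of carbon only, at the same place on the core, so a step no larger than the scatter, perhaps leaning toward a slightly higher number, is expected: a 1.7-fold higher number from compound 3 to compound 4 (0.22 log units; within the scatter).

Compound 4 is therefore estimated to give 4 nM in this assay, with a range from 1.5 nM to 12 nM.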

Compound 4, half-maximal inhibitory concentration: 1.2 nM
For compound 4 the middle estimate is 3.3-fold (0.52 log units) above the measured one; the measured number lies below the stated range.
By their numbers in this assay, from the lowest: compounds 4 and 3 (each within the scatter of the next); then compound 1; then compound 2.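

In this assay, putting phenoxy in place of phenethyl on an aromatic carbon, meta to a large group, gives a 2.0-fold lower number from compound 3 to compound 4 (0.30 log units; within the scatter), so the two compounds cannot be told apart in this read-out. Going by these compounds alone, this is the first measured pair to show that this position accepts the exchange: the single six-membered aromatic ring stays, the all-carbon group gives way to one that holds an oxygen and a hydrogen-bond acceptor, and the number stays within the scatter. Nothing shown explains why the two groups read alike here, and no measurement bears on a cause.

The compounds shown leave open how an amine in place of the oxygen of the phenoxy group, or a carboxylic acid on its aromatic ring, would read at this place. They also leave open whether the exchange would read the same way on another core, for this single pair is the only view of it, and one pair within the scatter sets no trend.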